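Cytotoxicity of benzylic analogues: a chlorothiophene replacement

This account rests on a few compounds, and the source may have more. Where it says the series, first, only, none or still open, it means among the compounds named here.

Measured so far in an ADME assay on MDBK cells (Bos taurus) for cytotoxicity; on this read-out higher numbers stand for lower toxicity in this test and lower numbers for higher toxicity in this test:
compound 1 `Brc1ccc(Cn2ccc3nc(-c4ccccc4)nc-3c2)cc1`: 83000 nM
compound 2 `N#Cc1ccc(Cn2ccc3nc(-c4ccccc4)nc-3c2)cc1`: > 100000 nM, a limit of the assay
compound 3 `c1ccc(CCCn2ccc3nc(-c4ccccc4)nc-3c2)cc1`: > 100000 nM, a limit of the assay

Compound 3 stands at the limit of this assay, so its value is a limit rather than a number. The same holds for (the limit of > 100000 nM in this assay, at which 2 of the 3 values shown sit). Compound 1 alone gives a number. Compound 4 `Clc1ccc(Cn2ccc3nc(-c4ccccc4)nc-3c2)s1` differs from compound 3 in one place: 5-chlorothiophen-2-yl in place of phenethyl on a saturated chain carbon bound to an aromatic nitrogen. The step of an at least 1.2-fold higher number from compound 1 to compound 3 (0.08 log units; that floor lies within the scatter) bears on this change, while a step that the two limits leave unreadable from compound 2 to compound 3 cannot be read. Since the step from a 4-bromophenyl ring to phenethyl stayed within the scatter, the return to a halogenated aromatic ring is expected to give no step beyond it, an at least 1.1-fold lower number from compound 3 to compound 4 (0.04 log units; that floor lies within the scatter). Compound 4 is therefore estimated at 90000 nM, between 40000 nM and 200000 nM, with a real chance of only a limit again.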

Compound 4, half-maximal cytotoxic concentration: > 100000 nM
Compound 4 ended at the assay's limit (the forecaster's own chance of this, stated with the estimate: 45%); middle value at least 1.1-fold (0.04 log units) away from the limit.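

In this assay compound 4 gives > 100000 nM, which is a limit of the assay and not a number. Going by these compounds alone, with 5-chlorothiophen-2-yl in place of 4-bromophenyl on this saturated chain carbon bound to an aromatic nitrogen, the one readable step is an at least 1.2-fold higher number from compound 1 to compound 4 (0.08 log units; that floor lies within the scatter). The steps linking compound 4 to compound 2 and compound 3 cannot be read, and the set now gathers at a single limit: the limit of > 100000 nM in this assay, at which 3 of the 4 values shown sit.

Going by these compounds, whether compound 2, compound 3 and compound 4 differ from one another stays open. So does what an amine or a carboxylic acid at this place would give.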